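This account rests on a few compounds, and the source may have more. Where it says the series, first, only, none or still open, it means among the compounds named here.

Compound 1 `C=CCc1cc(O)c(O)c(CN2CCC(CCO)CC2)c1` gives 54.4% of growth inhibition
Compound 2 `C=CCc1ccc(OCc2cn(-c3ccccc3CO)nn2)c(O)c1` gives 39.6% of growth inhibition

Within the data shown here, in a functional assay on MIA PaCa-2 cells (Homo sapiens) for inhibition, read by MTT assay, with a stated time of 72 h, tested at 30 uM (on this read-out higher numbers stand for more inhibition of growth at the one concentration tested and lower numbers for less inhibition of growth), compound 1 stands at 54.4% as the higher of the two numbers so far, and its gap to compound 2 lies beyond the usual scatter. Compound 3 `C=CCc1cc(O)c(O)c(CN2CCC(Cc3ccccc3)CC2)c1` has not yet been measured. It keeps the core of compound 1 and changes one place, with phenyl in place of hydroxymethyl on a saturated chain carbon bound to a saturated ring carbon so that, cut one bond further out, 2-hydroxyethyl gives way to benzyl. Among the measured compounds shown here, no measured pair differs in only one place, so nothing here fixes the size of this step, and any forecast is a judgement rather than a reading. In this assay a moderate upward step is expected, though a step lost in the scatter remains possible. The estimated change is a number 13.6 percentage points higher from compound 1 to compound 3 (beyond the scatter) and it carries wide uncertainty. For compound 3 the expected value is 68% with an estimated range of 45% to 92% until the measurement arrives.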

Compound 3, percent growth inhibition at one concentration: 88.9%
Compound 3: the middle estimate sits 20.9 percentage points below what was measured; the measured number falls inside the stated range.
By their numbers in this assay, from the lowest: compound 2; then compound 1; then compound 3.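

In this assay, putting phenyl in place of hydroxymethyl on a saturated chain carbon bound to a saturated ring carbon gives a number 34.5 percentage points higher from compound 1 to compound 3 (beyond the scatter), and this is the only pair shown that differs in just one place. It shows that what sits at this position can change the read-out strongly, which the earlier pair of compounds, differing in more than one place, could not show. The change swaps a group with 1 hydrogen-bond donor and 1 hydrogen-bond acceptor for one with 0 hydrogen-bond donors, 0 hydrogen-bond acceptors and one six-membered aromatic ring of carbon only, but nothing measured here tells which of these differences matters.

The compounds shown leave open whether the aromatic ring itself is needed, which a cyclohexyl group or a pyridyl ring at the same place would test. They also leave open how the number responds to a longer chain between the saturated ring and the phenyl, or to an amine in place of hydroxymethyl.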